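A few compounds are considered here, and "the series" means these few. Any claim that something is new, unique, unknown or untested is made for them only; others in the source may bear on it.

Working notes on the series. Going by the values given here, in an assay on isolated protein for inhibition of Norepinephrine transporter (Rattus norvegicus), read by radioligand binding (on this read-out higher numbers stand for weaker inhibition and lower numbers for stronger inhibition), compound 2 `CN1CCC(c2ccc(Cl)cc2)C(C[S+]([O-])CC(=O)NO)C1` gives 12 nM, the lower of the two numbers measured so far; the only other point is compound 1 `COCC[S+]([O-])CC1CN(C)CCC1c1ccc(Cl)cc1`, which in this assay gives 25 nM. Among the compounds with values here, the one measured step, a 2.1-fold lower number from compound 1 to compound 2 (0.32 log units; beyond the scatter), came with hydroxycarbamoyl in place of methoxymethyl on the saturated chain carbon bound to the sulfur.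

Compound 3 `CNC(=O)C[S+]([O-])CC1CN(C)CCC1c1ccc(Cl)cc1` is the next point. It differs from compound 2 by methyl in place of hydroxy on an amide-type nitrogen. The hydroxycarbamoyl end is what distinguished compound 2 from compound 1, and the change to compound 3 takes away the hydroxy portion of that group while leaving the carbonyl and the amide nitrogen in place. Within the data shown here, no measured pair shows an exchange on an amide nitrogen, so the only guide is the size of the single step to compound 2, which was modest. A partial return toward the number of compound 1 seems the most reasonable expectation, with no step beyond the scatter also possible. The expected step is a 1.7-fold higher number from compound 2 to compound 3 (0.22 log units; within the scatter). Compound 3 is therefore estimated at 20 nM, in a range from 8 nM to 50 nM.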

Compound 3, inhibition constant: 86 nM
Compound 3: the middle estimate sits 4.3-fold (0.63 log units) below what was measured, and the stated range ends below it.
By their numbers in this assay, from the lowest: compound 2; then compound 1; then compound 3.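

In this assay, going by these compounds alone, the group on the amide-type nitrogen matters more than the single earlier step suggested: methyl in place of hydroxy gives a 7.2-fold higher number from compound 2 to compound 3 (0.86 log units; beyond the scatter), a larger change than a 2.1-fold lower number from compound 1 to compound 2 (0.32 log units; beyond the scatter). The carbonyl and amide nitrogen alone do not account for the lower number of compound 2, since methylcarbamoyl in place of methoxymethyl gives a 3.4-fold higher number from compound 1 to compound 3 (0.54 log units; beyond the scatter), a move in the opposite direction from the one seen with hydroxycarbamoyl, and the three compounds now stand apart beyond the scatter, with compound 2 lowest and compound 3 highest. No independent measurement bears on the origin of these steps.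

The compounds shown leave open whether the step to compound 3 follows the loss of hydroxy or the arrival of methyl, and a plain carbamoyl end, with only hydrogen on the amide-type nitrogen, would separate the two. Also open, on these data alone, is how a methoxy on that nitrogen, or a carboxylic acid in place of the whole hydroxycarbamoyl end, would stand against compound 2 on the shared core.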